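Bromine on the Benzylidene Ring and a Longer Allyl Chain

This account rests on a few compounds, and the source may have more. Where it says the series, first, only, none or still open, it means among the compounds named here.

Three compounds were tested in a functional assay on MCF7 cells (Homo sapiens), tested at 7.5 uM; a lower number here means a stronger effect, a higher number a weaker effect of the compound at the concentration tested. Compound 1 `C=CCOc1c(C)c(C)c2c(c1C)CCC(C)(COc1ccc(/C=C3\SC(=O)NC3=O)cc1)O2` gives 2%. Compound 2 `CC(C)=CCOc1c(C)c(C)c2c(c1C)CCC(C)(COc1ccc(/C=C3\SC(=O)NC3=O)cc1)O2` differs from compound 1 by 2-methylprop-1-en-1-yl in place of vinyl on a saturated chain carbon bound to an oxygen on an aromatic ring and in this assay compound 2 gives 5%, a change of a number 3 percentage points higher from compound 1 to compound 2 (within the scatter). Compound 3 `C=CCOc1c(C)c(C)c2c(c1C)CCC(C)(COc1ccc(/C=C3\SC(=O)NC3=O)cc1Br)O2` differs from compound 1 by bromo in place of hydrogen on an aromatic carbon, and in this assay compound 3 gives 105%, a change of a number 103 percentage points higher from compound 1 to compound 3 (beyond the scatter); this leaves compound 3 with the highest number of the three, beyond the scatter against both others.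

Compound 4 `CC(C)=CCOc1c(C)c(C)c2c(c1C)CCC(C)(COc1ccc(/C=C3\SC(=O)NC3=O)cc1Br)O2` has not been measured. It differs from compound 3 by 2-methylprop-1-en-1-yl in place of vinyl on a saturated chain carbon bound to an oxygen on an aromatic ring, which is the same change as that from compound 1 to compound 2, at the same place. That earlier step was a number 3 percentage points higher from compound 1 to compound 2 (within the scatter), within the scatter. The expected step here is therefore also small, about a number 2 percentage points lower from compound 3 to compound 4 (within the scatter), because the move from compound 1 to compound 2 gave only a number 3 percentage points higher from compound 1 to compound 2 (within the scatter) while the bromine in compound 3 already gave 105%. Compound 4 is estimated at 103%, with a range from 88% to 118%.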

Compound 4, a percentage reported as activity, at one concentration (the size of the read-out at that concentration, not a potency): 53%
The estimate for compound 4 lay 50 percentage points above the measured number, outside the stated range (below it).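

In this assay, the swap from allyl to 3-methylbut-2-en-1-yl on the bromo core gives a number 52 percentage points lower from compound 3 to compound 4 (beyond the scatter), while adding the bromo group to the core of compound 2 gives a number 48 percentage points higher from compound 2 to compound 4 (beyond the scatter). The chain swap therefore cannot be carried from one core to the other and be expected to keep its size, since it does almost nothing without the bromo group but a great deal with it: the same change on two cores in this assay, a number 3 percentage points higher (within the scatter) from compound 1 to compound 2 and a number 52 percentage points lower (beyond the scatter) from compound 3 to compound 4, 55 percentage points apart, beyond the scatter of two such steps
The bromo group raises the number on both cores, yet by different amounts, and these four compounds show only that the two changes depend on each other, not why they do: the same change on two cores in this assay, a number 103 percentage points higher (beyond the scatter) from compound 1 to compound 3 and a number 48 percentage points higher (beyond the scatter) from compound 2 to compound 4, 55 percentage points apart, beyond the scatter of two such steps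

As far as these compounds go, it remains open whether chloro in place of bromo would show the same dependence on the chain. From the compounds shown here alone, it is also open whether a longer chain in place of 3-methylbut-2-en-1-yl would lower the number further on the bromo core.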